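From compound 3 to compound 4: the expected step

The compounds below may be only part of what the source reports. "The series", "measured", "known", "first", "only" and "open" are said of these compounds alone.

Measured so far in a functional assay, read by spectrophotometry, tested at 100 uM; on this read-out higher numbers stand for weaker inhibition and lower numbers for stronger inhibition
compound 1 `COc1ccc(/C=C/C(=O)c2cccc(NC(=O)c3cc(-c4ccncc4)n[nH]3)c2)cc1` gives 38400 nM
compound 2 `O=C(/C=C/c1ccccc1Cl)c1cccc(NC(=O)c2cc(-c3ccncc3)n[nH]2)c1` gives 27700 nM
compound 3 `COc1cc(/C=C/C(=O)c2cccc(NC(=O)c3cc(-c4ccncc4)n[nH]3)c2)cc(OC)c1OC` gives 54500 nM

Compound 3 stands at 54500 nM and, on these numbers, cannot be separated from compound 1 or compound 2. The next change leads to compound 4 `O=C(/C=C/c1ccc(Cl)cc1Cl)c1cccc(NC(=O)c2cc(-c3ccncc3)n[nH]2)c1` and reads (2,4-dichlorophenyl in place of 3,4,5-trimethoxyphenyl on a double-bonded chain carbon bound to a double-bonded chain carbon). The three measured compounds differ from one another at this same place, so three steps bear on the change: a 1.4-fold lower number from compound 1 to compound 2 (0.14 log units; within the scatter), a 1.4-fold higher number from compound 1 to compound 3 (0.15 log units; within the scatter) and a 2.0-fold higher number from compound 2 to compound 3 (0.29 log units; within the scatter). All three stay within the scatter, across 4-methoxyphenyl, 2-chlorophenyl and 3,4,5-trimethoxyphenyl. Among the compounds with values here, no measured compound carries 2,4-dichlorophenyl. The nearest group by name is the 2-chlorophenyl of compound 2, which gives 27700 nM, so the estimate leans towards that value. No step beyond the scatter is expected in this assay, and any movement would be expected towards a lower number. The estimated step is a 1.7-fold lower number from compound 3 to compound 4 (0.23 log units; within the scatter). For compound 4 the expected value is 32000 nM, with an estimated range from 14000 nM to 70000 nM.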

Compound 4, half-maximal inhibitory concentration: 35000 nM
For compound 4 the middle estimate is 1.1-fold (0.04 log units) below the measured one; the range from low to high includes it.
By their numbers in this assay, from the lowest: compounds 2, 4, 1 and 3 (each within the scatter of the next).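

In this assay, replacing the 3,4,5-trimethoxyphenyl with 2,4-dichlorophenyl exchanges a group with hydrogen-bond acceptors for one with none, and chlorine enters where oxygen stood, yet the result is a 1.6-fold lower number from compound 3 to compound 4 (0.19 log units; within the scatter). Chloro in place of hydrogen on an aromatic carbon gives the first single-substituent comparison at this place, a 1.3-fold higher number from compound 2 to compound 4 (0.10 log units; within the scatter), and 2,4-dichlorophenyl in place of 4-methoxyphenyl gives a 1.1-fold lower number from compound 1 to compound 4 (0.04 log units; within the scatter), so neither adding this chloro nor exchanging methoxy for chlorine separates the compounds. All four aromatic groups on the double-bonded chain carbon therefore remain inseparable on this read-out, including the pair that differs by a single chloro, and no measurement at hand accounts for this flat picture.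

On these data alone, it remains open whether a group of a different kind at this place, such as an amine or a carboxylic acid on the phenyl ring or a longer chain in place of that ring, would produce a step beyond the scatter. As far as these compounds go, it also remains open whether a change elsewhere on the shared core would move the number further than any change at this place has so far.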